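Two Chain Stereocentres Left Without Drawn Configuration

The source may hold more compounds than are shown below. What is called first, only, known or untested is meant among the compounds shown, and "the series" means these compounds.

Of the compounds shown here, three sharing one core have been tested in a functional assay on the whole organism (strain Wistar) for inhibition, with Rattus norvegicus as the target, read by paw edema, with a stated time of 1 h, at a dose of 10 mg/kg by the intraperitoneal route; a higher number here means more inhibition at the dose given (going by the name of the read-out), a lower number less inhibition. Compound 1 `COc1cc(/C=C/C(=O)/C=C(O)/C=C/c2ccc(OC(=O)[C@H](CCC(N)=O)NC(=O)OCc3ccccc3)c(OC)c2)ccc1OC(=O)[C@H](CCC(N)=O)NC(=O)OCc1ccccc1` gives 51%. Compound 2 `COc1cc(/C=C/C(=O)/C=C(O)/C=C/c2ccc(OC(=O)[C@H](C)NC(=O)OC(C)(C)C)c(OC)c2)ccc1OC(=O)[C@H](C)NC(=O)OC(C)(C)C` gives 6%, and compound 3 `COc1cc(/C=C/C(=O)/C=C(O)/C=C/c2ccc(OC(=O)[C@@H](C)NC(=O)OC(C)(C)C)c(OC)c2)ccc1OC(=O)[C@@H](C)NC(=O)OC(C)(C)C` gives 22%. Compound 3 thus stands second highest of the three numbers, with compound 1 farther from it than compound 2. Going by the values given here, the only measured step is a number 16 percentage points higher from compound 2 to compound 3 (beyond the scatter), and the sole thing that separates those two compounds is the fact that compounds 2 and 3 differ only in the configuration as drawn. Compound 4 `COc1cc(/C=C/C(=O)/C=C(O)/C=C/c2ccc(OC(=O)C(C)NC(=O)OC(C)(C)C)c(OC)c2)ccc1OC(=O)C(C)NC(=O)OC(C)(C)C` keeps the same atoms and bonds as compound 3 and differs only in that (the two compounds have the same atoms and bonds; at least one stereo element is drawn with a configuration in one of them and without one in the other: 2 of 5 stereo elements differ; a stereocentre at a saturated chain carbon is drawn R in compound 3 and without a configuration in compound 4; a stereocentre at a saturated chain carbon is drawn R in compound 3 and without a configuration in compound 4). That measured step bears directly on this change, because a number 16 percentage points higher from compound 2 to compound 3 (beyond the scatter) shows that flipping both centres shifts the number modestly; a compound drawn without either configuration is expected to land between compound 2 and compound 3. Compound 4 is therefore estimated at 14%, with a range from 3% to 28%. The expected step of a number 8 percentage points lower from compound 3 to compound 4 (within the scatter) is a small drop that is not expected to exceed the usual scatter.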

Compound 4, a percentage reported as inhibition, in the whole organism at one dose (the size of the read-out at that dose, not a potency): 11%
Compound 4: the middle estimate sits 3 percentage points above what was measured; low and high end bracket the measured number.
By their numbers in this assay, from the lowest: compounds 2 and 4 (each within the scatter of the next); then compound 3; then compound 1.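

In this assay, the compound drawn without configuration at the two chain stereocentres cannot be told apart from the compound drawn S at both, with a number 5 percentage points higher from compound 2 to compound 4 (within the scatter). Against the compound drawn R at both, the picture differs, with a number 11 percentage points lower from compound 3 to compound 4 (beyond the scatter), so among these three alanine-type esters only compound 3 stands clear of the other two. That gap therefore comes with nothing changed but the drawing of the two centres: the fact that one of compounds 3 and 4 is drawn with a defined configuration and the other without, at the place where they differ

A drawing without configuration does not say which forms the sample of compound 4 holds, and a form drawn R at one centre and S at the other is not among those shown. On these data alone, it also stays open whether configuration matters to the same extent with a free amine on these chain carbons, or with a longer chain in place of the methyl.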